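The source may hold more compounds than are shown below. What is called first, only, known or untested is meant among the compounds shown, and "the series" means these compounds.

In a functional assay on HeLa cells (Homo sapiens) for cytotoxicity, read by sulforhodamine B assay, with a stated time of 72 h (on this read-out higher numbers stand for weaker inhibition and lower numbers for stronger inhibition), compound 3 `C=CCOc1cccc(/C=C/C(=O)Nc2cc(OC)c(OC)c(OC)c2)c1` gives 5400 nM and compound 1 `COc1cc(NC(=O)/C=C/c2cccc(OC(F)(F)F)c2)cc(OC)c1OC` gives 4400 nM, two values within the scatter of each other. Compound 2 `COc1cc(NC(=O)/C=C/c2ccccc2)cc(OC)c1OC` reads > 50000 nM, which is a limit of the assay. Compound 4 `COc1cc(NC(=O)/C=C/c2cccc(OCc3ccccc3)c2)cc(OC)c1OC` differs from compound 3 by phenyl in place of vinyl on a saturated chain carbon bound to an oxygen on an aromatic ring. Large steps came with removing the whole substituent, as in an at least 11-fold higher number from compound 1 to compound 2 (1.05 log units; beyond the scatter) and an at least 9.2-fold lower number from compound 2 to compound 3 (0.96 log units; beyond the scatter). Exchanging the group on the oxygen gave only a 1.2-fold higher number from compound 1 to compound 3 (0.09 log units; within the scatter). In this assay, no step beyond the scatter is therefore expected, and the expected change is a 1.2-fold lower number from compound 3 to compound 4 (0.08 log units; within the scatter). Compound 4 is estimated at 4500 nM, within an expected range of 1500 nM to 14000 nM.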

Compound 4, half-maximal inhibitory concentration: 2100 nM
For compound 4 the middle estimate is 2.1-fold (0.33 log units) above the measured one; the range from low to high includes it.
By their numbers in this assay, from the lowest: compound 4; then compounds 1 and 3 (each within the scatter of the next). At a limit, above all of these: compound 2.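

In this assay, exchanging the group on the oxygen now gives steps beyond the scatter, which the earlier exchange did not: phenyl in place of vinyl gives a 2.6-fold lower number from compound 3 to compound 4 (0.41 log units; beyond the scatter), and benzyl in place of trifluoromethyl gives a 2.1-fold lower number from compound 1 to compound 4 (0.32 log units; beyond the scatter). Adding the benzyloxy group gives an at least 23-fold lower number from compound 2 to compound 4 (1.37 log units; beyond the scatter). The value of compound 2 in that step is a limit, not a number: the limit of > 50000 nM in this assay, at which 1 of the 4 values shown sits.

Going by these compounds, whether a phenethyl or a pyridylmethyl group on the same oxygen would read lower or higher stays open. So does what an amine or a carboxylic acid in that place would give.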